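The source may report more compounds than this note shows. Statements on the series, on what has been measured and on what is new or still open speak of the compounds shown alone.

Measured so far:
Compound 1, `CC(O)(C(=O)Nc1ccc(S(=O)(=O)N2CCCC2)cc1)C(F)(F)F`: 880 nM
Compound 2, `CC(O)(C(=O)Nc1ccc(-c2nn[nH]n2)cc1)C(F)(F)F`: > 30000 nM
Compound 3, `CN(C)S(=O)(=O)c1ccc(NC(=O)C(C)(O)C(F)(F)F)cc1`: 480 nM

In an assay on a protein complex (Cavia porcellus) with sulfonylurea receptors; K-ATP channels (Homo sapiens) as the target (on this read-out higher numbers stand for weaker inhibition and lower numbers for stronger inhibition), compound 3 has the lowest of the two numbers, with compound 1 nearest at a 1.8-fold lower number from compound 1 to compound 3 (0.26 log units; within the scatter), so the two are not separated. The value of compound 2 is a limit of the assay, not a number, because it sits at the limit of > 30000 nM in this assay, at which 1 of the 3 values shown sits.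

Compound 4, `CC(O)(C(=O)Nc1ccc(S(N)(=O)=O)cc1)C(F)(F)F`, differs from compound 3 in one place: amino in place of dimethylamino on a sulfonyl sulfur. The step that bears on it is the earlier change on the same sulfonyl sulfur, a 1.8-fold lower number from compound 1 to compound 3 (0.26 log units; within the scatter), which stayed within the scatter; the large steps of an at least 34-fold higher number from compound 1 to compound 2 (1.53 log units; beyond the scatter) and an at least 62-fold lower number from compound 2 to compound 3 (1.79 log units; beyond the scatter) exchanged the whole group on the aromatic carbon and speak less to this smaller change. Compound 4 is therefore expected to show a 1.5-fold higher number from compound 3 to compound 4 (0.16 log units; within the scatter), no step beyond the scatter. The estimate for compound 4 is 700 nM, between 250 nM and 2000 nM.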

Compound 4, half-maximal inhibitory concentration: 12800 nM
Compound 4: middle estimate off by 18-fold (1.26 log units), on the low side; measured number above the stated range.
By their numbers in this assay, from the lowest: compounds 3 and 1 (each within the scatter of the next); then compound 4. At a limit, above all of these: compound 2.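

On the sulfonyl sulfur, the choice of group does matter in this assay: dimethylamino and pyrrolidin-1-yl stayed within the scatter of each other, but amino brings a 27-fold higher number from compound 3 to compound 4 (1.43 log units; beyond the scatter) and a 15-fold higher number from compound 1 to compound 4 (1.16 log units; beyond the scatter). On the aromatic carbon, sulfamoyl compares with 2H-tetrazol-5-yl as an at least 2.3-fold lower number from compound 2 to compound 4 (0.36 log units; beyond the scatter). The value of compound 2 is a limit and not a number: the limit of > 30000 nM in this assay, at which 1 of the 4 values shown sits.

The compounds shown leave open whether methylamino on the same sulfonyl sulfur would fall with amino or with dimethylamino. They also leave open how a morpholine group there would read.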